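The source may report more compounds than this note shows. Statements on the series, on what has been measured and on what is new or still open speak of the compounds shown alone.

Measured compounds:
Compound 1 `O=c1c(Cl)c(CSC(=S)N2CCOCC2)oc2ccccc12` gives 11100 nM in a functional assay on MCF7 cells (Homo sapiens) for antiproliferative activity, read by MTT assay, with a stated time of 72 h; on this read-out higher numbers stand for weaker inhibition and lower numbers for stronger inhibition.
Compound 2 `CCOC(=O)c1cc(=O)c2cc(CSC(=S)N(C)c3ccccc3)ccc2o1` reaches only the assay limit of > 25000 nM in this assay.
Compound 3 `CCOC(=O)c1cc(=O)c2cc(CSC(=S)N(C(C)C)C(C)C)ccc2o1` also reaches only the assay limit of > 25000 nM in this assay.

Among the measured compounds shown here, compound 1 is thus the one compound of the three with a number; the other two values are limits, as the limit of > 25000 nM in this assay, at which 2 of the 3 values shown sit, shows. For the measured compounds named here, the single step between measured compounds, a step that the two limits leave unreadable from compound 2 to compound 3, sits on a core different from that of compound 1 and cannot be read because both of its ends are limits. Compound 4 `O=c1c(Cl)c(CSC(=S)N2CCCC2)oc2ccccc12` differs from compound 1 in one place: pyrrolidin-1-yl in place of morpholin-4-yl on a thiocarbonyl carbon. Going by the values given here, no measured step involves either morpholin-4-yl or pyrrolidin-1-yl on the shared core of compound 1, so no step bears on this change, and the expectation for compound 4 rests on compound 1 alone, with a wide range. The step is therefore expected to stay within the scatter, a 1.0-fold lower number from compound 1 to compound 4 (0.00 log units; within the scatter), in no particular direction. The estimate for compound 4 is 11000 nM, expected to lie between 4000 nM and 30000 nM.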

Compound 4, half-maximal inhibitory concentration: 2300 nM
Compound 4: middle estimate off by 4.8-fold (0.68 log units), on the high side, outside the stated range (below it).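

On the shared core of compound 1, the thiocarbonyl carbon now carries a step that can be read: in this assay there is a 4.8-fold lower number from compound 1 to compound 4 (0.68 log units; beyond the scatter). The earlier compounds shown here, one number and two limits, could not show that this position responds to a change of ring, here pyrrolidin-1-yl, a five-membered ring with one hetero atom, in place of morpholin-4-yl, a six-membered ring with two hetero atoms. The change alters ring size and hetero atom count together, and nothing measured here gives a cause for the step.

Going by these compounds, whether ring size or the ring oxygen carries the step stays open, and piperidin-1-yl on the shared core would separate the two. Also open, on these data alone, is whether an open-chain group such as diethylamino on the thiocarbonyl carbon would keep the lower number.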